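Series notes: methoxy for methyl on the compound 1 core

This account rests on a few compounds, and the source may have more. Where it says the series, first, only, none or still open, it means among the compounds named here.

Of the compounds shown here, three have been measured in a functional assay on HCT-116 cells (Homo sapiens) for inhibition, read by MTT assay, with a stated time of 72 h; a lower number here means a stronger inhibitor of growth, a higher number a weaker inhibitor of growth. Compound 1 `COC1=C(C)C(=O)C(CCCCCCCCCCn2cc(C[C@H](O)COCCOC[C@@H](O)Cc3ccc(-c4ccccc4)cc3)nn2)=C(C)C1=O` gives 4000 nM, the lowest of the three numbers. Compound 3 `COC1=C(OC)C(=O)C(CCCCCCn2cc(C[C@H](O)COCCOC[C@@H](O)Cc3ccc(-c4ccccc4)cc3)nn2)=C(C)C1=O` gives 5000 nM, which lies within the scatter of compound 1. Compound 2 `O=c1[nH]c2ccc(-n3cc(C[C@H](O)COCCOC[C@@H](O)Cc4ccc(-c5ccccc5)cc4)nn3)cc2s1` gives 9200 nM, beyond the scatter relative to compound 1, so compound 2 stands as the weaker inhibitor of growth of the three.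

The next compound, compound 4 `COC1=C(OC)C(=O)C(CCCCCCCCCCn2cc(C[C@H](O)COCCOC[C@@H](O)Cc3ccc(-c4ccccc4)cc3)nn2)=C(C)C1=O`, differs from compound 1 in one place: methoxy in place of methyl on a double-bonded ring carbon. Among the compounds with values here, no measured pair in the set differs in only this way, so the size of the step is not known directly. The core of compound 3, which resembles that of compound 4, returned a number within the scatter of compound 1, and nothing here points to a large effect of a methoxy in place of methyl on a double-bonded ring carbon. The expected step from compound 1 to compound 4 in this assay, a 1.1-fold higher number from compound 1 to compound 4 (0.05 log units; within the scatter), is therefore small, with no direction beyond the scatter. Compound 4 is estimated at 4500 nM, with a range from 2500 nM to 8500 nM.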

Compound 4, concentration for 50% growth inhibition: 600 nM
Compound 4: the middle estimate sits 7.5-fold (0.88 log units) above what was measured; the whole stated range lies above it.
By their numbers in this assay, from the lowest: compound 4; then compounds 1, 3 and 2 (each within the scatter of the next, the first and the last beyond it).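

In this assay, methoxy in place of methyl on a double-bonded ring carbon gives a 6.7-fold lower number from compound 1 to compound 4 (0.82 log units; beyond the scatter) and so shows that this one position on the shared core can move the number beyond the scatter. The methoxy does not fix the number by itself: compound 3, which carries the same methoxy on its core with a shorter chain, gives 5000 nM against the lower number of compound 4 at 600 nM in the same assay. Nothing available gives a measured reason for the step.

Going by these compounds, whether ethoxy or an amine on the same ring carbon would keep this gain remains open. Also open, on these data alone, is whether a longer chain on the core of compound 4 would lower the number further or raise it.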